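Adding an Isopropyl Arm to a Glycine Side Chain

The compounds below may be only part of what the source reports. "The series", "measured", "known", "first", "only" and "open" are said of these compounds alone.

Compound 2 `CC1=CCC[C@](C)(CC/C(C)=C/CC2=C(O)C(=O)C=C(NCC(=O)O)C2=O)[C@@H]1C` is the starting point. In an ADME assay on L1210 cells (Mus musculus) for cytotoxicity, with a stated time of 48 h (a higher number here means a weaker inhibitor, a lower number a stronger inhibitor), compound 2 gives 3.5 ug/mL, the lower of the two numbers obtained, although compound 1 `CC1=CCC[C@H]2[C@](C)(CC3=C(O)C(=O)C=C(N[C@@H](CO)C(=O)O)C3=O)[C@@H](C)CC[C@]12C` gives 3.8 ug/mL, which lies within the usual scatter of that result. Compound 3 `C=C1[C@H](C)CCC[C@]1(C)CC/C(C)=C/CC1=C(O)C(=O)C=C(N[C@H](C(=O)O)[C@@H](C)O)C1=O` reaches only a limit, > 10 ug/mL, in this assay; the limit of > 10 ug/mL in this assay, at which 1 of the 3 values shown sits, marks where it sits. Compound 4 `CC1=CCC[C@](C)(CC/C(C)=C/CC2=C(O)C(=O)C=C(N[C@@H](C(=O)O)C(C)C)C2=O)[C@@H]1C` is the untested partner: isopropyl in place of hydrogen on a saturated chain carbon bound to an amine nitrogen and a carbonyl carbon. Among the compounds with values here, no measured pair shows this exact change, and compound 1 and compound 3, which also carry a group in place of that hydrogen, differ from compound 2 elsewhere too, so only a small step in this assay is expected, leaning toward a weaker inhibitor. Compound 4 is estimated at 5 ug/mL, expected to lie between 2.5 ug/mL and 10 ug/mL. The expected step of a 1.4-fold higher number from compound 2 to compound 4 (0.15 log units; within the scatter) is therefore modest.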

Compound 4, half-maximal inhibitory concentration: 3 ug/mL
Compound 4: middle estimate off by 1.7-fold (0.22 log units), on the high side; the measured number falls inside the stated range.
By their numbers in this assay, from the lowest: compounds 4, 2 and 1 (each within the scatter of the next). At a limit, above all of these: compound 3.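

Putting isopropyl in place of hydrogen on a saturated chain carbon bound to an amine nitrogen and a carbonyl carbon gives a 1.2-fold lower number from compound 2 to compound 4 (0.07 log units; within the scatter) in this assay and so leaves the number within the scatter. Within the data shown here, this is the first pair that isolates this change, since compound 1 and compound 3 differ from compound 2 elsewhere too. At this position, the isopropyl arm can be added to compound 2 without a measurable loss in this read-out.

From the compounds shown here alone, whether a longer chain or an amine on the same carbon would behave alike stays open. Nothing measured here gives a reason for the result.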